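This account rests on a few compounds, and the source may have more. Where it says the series, first, only, none or still open, it means among the compounds named here.

The measured compounds:

compound 1 `CC1CCCCC1C(=O)N1CC(c2nc(-c3cccc(F)c3)no2)C1`, 540 nM
compound 2 `CC1CCN(C(=O)N2CC(c3nc(-c4cccc(Cl)c4)no3)C2)CC1`, 865 nM
compound 3 `Cc1cccc(-c2noc(C3CN(S(=O)(=O)c4ccc(Cl)cc4)C3)n2)c1`, for which only a limit, > 10000 nM, is recorded

In an assay on HEK293 cells for positive allosteric modulation of metabotropic glutamate receptor 5 (Homo sapiens), read by FLIPR (on this read-out lower numbers stand for an effect already at smaller amounts and higher numbers for an effect only at larger amounts of compound), compound 1 gives 540 nM. Compound 2 gives 865 nM in this assay, and the two numbers lie within the usual scatter of each other, so neither can be placed ahead of the other. For compound 3 the result is a limit, (the limit of > 10000 nM in this assay, at which 1 of the 3 values shown sits), and not a number. Compound 1 therefore sits among the two numbers, with the sulfonyl analogue compound 3 at the limit.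

The unmeasured compound 4 `O=C([C@@H]1CC2CCC1C2)N1CC(c2nc(-c3cccc(F)c3)no2)C1` differs from compound 1 in one place: a group of 7 heavy atoms (7 carbon; 2 five-membered non-aromatic rings of carbon only) in place of a group of 7 heavy atoms (7 carbon; one six-membered non-aromatic ring of carbon only), on a carbonyl carbon. Among the measured compounds shown here, no step between measured compounds of this kind is available, so the expectation rests only on the change itself, which keeps the count of heavy atoms and the non-aromatic carbon-only character of the group on the carbonyl carbon. Compound 4 is expected at about 600 nM in this assay, with a range from 250 nM to 1500 nM. The step of a 1.1-fold higher number from compound 1 to compound 4 (0.05 log units; within the scatter) is expected to stay within the scatter, in no particular direction.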

Compound 4, half-maximal effective concentration: 100 nM
The estimate for compound 4 lay 6.0-fold (0.78 log units) above the measured number; measured number outside the range, below it.
By their numbers in this assay, from the lowest: compound 4; then compounds 1 and 2 (each within the scatter of the next). At a limit, above all of these: compound 3.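

On the carbonyl carbon whose other neighbours are the amide-type nitrogen in a ring, replacing 2-methylcyclohexyl with the group of 2 five-membered non-aromatic rings of carbon only gives a 5.4-fold lower number from compound 1 to compound 4 (0.73 log units; beyond the scatter) in this assay. Among the compounds shown here, both groups hold 7 heavy atoms, all carbon, with no hydrogen-bond donors or acceptors and no net charge, so this position responds to a change in ring make-up even with those counts held constant, something the earlier compounds could not show, as no two of them differed in one place only. Nothing in the evidence given here bears on the origin of this step.

The compounds shown leave open whether the step belongs to the ring make-up itself or to the defined stereocentre of the entering group, as only one form of that group appears here. They also leave open how the same carbonyl carbon would respond to an open group such as tert-butyl, or to a ring holding other atoms, such as morpholine, with the rest of compound 4 kept.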